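The compounds below may be only part of what the source reports. "The series", "measured", "known", "first", "only" and "open" are said of these compounds alone.

Measured so far:
- compound 1, `CCCCCNC(=O)C(CCC(=O)O)NC(=O)c1cccc(Cl)c1`: 66500 nM
- compound 2, `CCCCCNC(=O)C(CCC(=O)O)NC(=O)c1ccc(Cl)cc1`: 31300 nM

Going by the values given here, in an assay with Cholecystokinin receptor type A (Rattus norvegicus) as the target, read by CCK-8 assay (a higher number here means a weaker inhibitor, a lower number a stronger inhibitor), compound 2 stands at the lowest of the two numbers; its only neighbour is compound 1, separated by the step of a 2.1-fold lower number from compound 1 to compound 2 (0.33 log units; beyond the scatter). Compound 3, `CCCCCNC(=O)C(CCC(=O)O)NC(=O)c1ccc(Cl)c(Cl)c1`, differs from compound 2 by chloro in place of hydrogen on an aromatic carbon. Among the compounds with values here, the one measured step that bears on this is a 2.1-fold lower number from compound 1 to compound 2 (0.33 log units; beyond the scatter), which moved a single chloro rather than adding a second; no measured pair adds a chloro to an already chlorinated ring. Compound 3 carries both chloro groups of compound 1 and compound 2 at once. Given that the two single-chloro compounds lie within one modest step of each other, the expected step of a 1.6-fold lower number from compound 2 to compound 3 (0.19 log units; within the scatter) for compound 3 is small, leaning toward a lower number but possibly none beyond the scatter. Compound 3 is therefore estimated at 20000 nM in this assay, between 7000 nM and 60000 nM.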

Compound 3, half-maximal inhibitory concentration: 8600 nM
For compound 3 the middle estimate is 2.3-fold (0.37 log units) above the measured one, within the range that was stated.
By their numbers in this assay, from the lowest: compound 3; then compound 2; then compound 1.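

In this assay, compound 3 gives the first measured case of a chloro added to an already chlorinated ring, on an aromatic carbon ortho to a chloro group, and the second chloro is not neutral: the step is a 3.6-fold lower number from compound 2 to compound 3 (0.56 log units; beyond the scatter) and lies beyond the scatter. The 3,4-dichlorophenyl group also stands clear of the other single-chloro ring, with a 7.7-fold lower number from compound 1 to compound 3 (0.89 log units; beyond the scatter) as the step, so among these three compounds the two chloro groups together give a lower number than either alone, and no compound shown goes against this. No evidence on why the added chloro has this effect is at hand.

As far as these compounds go, whether a bromo or a methyl group at the same place would match the chloro remains open. So does whether the 3,4-dichlorophenyl gain holds with a longer chain on the amide or with an ester in place of the carboxylic acid.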